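Fluoro in Place of Hydrogen on Compound 2

This account rests on a few compounds, and the source may have more. Where it says the series, first, only, none or still open, it means among the compounds named here.

In a functional assay on HCT-116 cells (Homo sapiens) for antiproliferative activity, read by MTT assay, with a stated time of 48 h (on this read-out lower numbers stand for stronger inhibition and higher numbers for weaker inhibition), compound 2 `COc1ccc(CN(C(=O)CSc2nc3ccccc3s2)c2cc(OC)c(OC)c(OC)c2)cc1` gives 426 nM. Compound 3 `COc1ccc(CN(C(=O)CSc2nc3c(C)cccc3s2)c2cc(OC)c(OC)c(OC)c2)cc1O` gives 852 nM, within the usual scatter of compound 2, though it is not a single change away from compound 2. Compound 1 `COc1ccc(CN(C(=O)CSc2nc3ccccc3s2)c2cc(OC)c(OC)c(OC)c2)cc1C` gives 17100 nM, far from both.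

Compound 4 `COc1ccc(CN(C(=O)CSc2nc3ccccc3s2)c2cc(OC)c(OC)c(OC)c2)cc1F` carries one change from compound 2: fluoro in place of hydrogen on an aromatic carbon. Among the compounds with values here, only one measured step bears on this carbon, ortho to a methoxy group: a 40-fold lower number from compound 1 to compound 2 (1.60 log units; beyond the scatter), a large step beyond the scatter, with hydrogen in place of methyl. Fluoro is a different group, so that step is only a loose guide. A much smaller step is expected in this assay, leaning toward a higher number. The estimated step is a 1.8-fold higher number from compound 2 to compound 4 (0.25 log units; within the scatter). Compound 4 is expected at 750 nM, within a range of 250 nM to 4000 nM.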

Compound 4, half-maximal inhibitory concentration: 1830 nM
For compound 4 the middle estimate is 2.4-fold (0.39 log units) below the measured one, and the stated range covers the measured number.
By their numbers in this assay, from the lowest: compounds 2 and 3 (each within the scatter of the next); then compound 4; then compound 1.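

In this assay, this carbon responds to fluoro as well as to methyl, with a 4.3-fold higher number from compound 2 to compound 4 (0.63 log units; beyond the scatter), so a small atom in place of hydrogen is already enough to weaken the result. Fluoro is still better accepted than methyl here, with a 9.3-fold lower number from compound 1 to compound 4 (0.97 log units; beyond the scatter), which places the three groups in a clear order, with hydrogen giving the lowest number. Nothing measured here explains these steps. Going by these compounds, whether a chloro group or an amine on this carbon would match compound 2 stays open, as does whether the order of hydrogen, fluoro and methyl would hold for them.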